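A methoxy in place of hydrogen on compound 2

The source may hold more compounds than are shown below. What is called first, only, known or untested is meant among the compounds shown, and "the series" means these compounds.

In a functional assay on CCRF-CEM cells (Homo sapiens) for inhibition (on this read-out higher numbers stand for weaker inhibition and lower numbers for stronger inhibition), compound 1 `O=C(CCCCC[S+]([O-])c1ccccc1)NO` gives > 25000 nM as its result, which is a limit and not a number. In this assay compound 3 `O=C(CCCCCC[S+]([O-])c1ccc(Cl)cc1)NO` gives 12300 nM as a measured number. Compound 2 `O=C(/C=C/C=C/C[S+]([O-])c1ccccc1)NO` stands as "not determined" (no result reported) in this assay and so offers no number of its own as a starting point.

The compound still awaiting measurement is compound 4 `COc1ccc([S+]([O-])C/C=C/C=C/C(=O)NO)cc1`, and it comes from a single change. The step methoxy in place of hydrogen on an aromatic carbon places methoxy in place of hydrogen on an aromatic carbon, para to a large group. Among the measured compounds shown here, no measured pair shows what such a change does, so no step beyond the usual scatter is expected in this assay and no direction is assumed. For the measured compounds named here, the expectation therefore leans on compound 3 at 12300 nM as the only true number available. Compound 4 is expected near 14000 nM in this assay, with an estimated range from 4000 nM to 30000 nM as its likely span.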

Compound 4, half-maximal inhibitory concentration: 9600 nM
The estimate for compound 4 lay 1.5-fold (0.16 log units) above the measured number; the measured number falls inside the stated range.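

Among the compounds shown here, compound 2 has no reported result in this assay, so no step from it to compound 4 at 9600 nM can be read. What methoxy in place of hydrogen does to inhibition stays open, and compound 1 offers only a limit, not a number: the limit of > 25000 nM in this assay, at which 1 of the 4 values shown sits.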